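Chloro to Trifluoromethyl: Expected Shift in Solubility

The source may report more compounds than this note shows. Statements on the series, on what has been measured and on what is new or still open speak of the compounds shown alone.

Compound 1 `Cc1cc(C)cc(NC(=O)COc2cc(C)nc3ccccc23)c1` gives 55000 nM in a physicochemical assay for solubility, in phosphate buffer, measured as kinetic solubility, with a stated time of 1 h, at pH 7.4; on this read-out lower numbers stand for lower solubility and higher numbers for higher solubility.
Compound 2 `Cc1cc(C)cc(NC(=O)COc2cc(C)nc3ccc(F)cc23)c1` gives 28000 nM in this assay.
Compound 3 `Cc1cc(C)cc(NC(=O)COc2cc(C)nc3ccc(Cl)cc23)c1` gives 8000 nM in this assay.

Of these three numbers, compound 3 stands lowest. The two steps that lead down to it are a 6.9-fold lower number from compound 1 to compound 3 (0.84 log units; beyond the scatter) and a 3.5-fold lower number from compound 2 to compound 3 (0.54 log units; beyond the scatter), both beyond the scatter; the step between compound 1 and compound 2 is a 2.0-fold lower number from compound 1 to compound 2 (0.29 log units; within the scatter), which is within the scatter.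

Compound 4 `Cc1cc(C)cc(NC(=O)COc2cc(C)nc3ccc(C(F)(F)F)cc23)c1` is the next compound, and it differs from compound 3 by trifluoromethyl in place of chloro on an aromatic carbon. The two steps that bear on this change are the ones that put a heavier group at the same place: a 6.9-fold lower number from compound 1 to compound 3 (0.84 log units; beyond the scatter) and a 3.5-fold lower number from compound 2 to compound 3 (0.54 log units; beyond the scatter). Both moved the number down by a modest amount, so a further modest decrease in this assay is expected for compound 4, estimated as a 2.7-fold lower number from compound 3 to compound 4 (0.43 log units; beyond the scatter). Compound 4 is therefore expected to give about 3000 nM, with a range from 1000 nM to 9000 nM.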

Compound 4, solubility: 10000 nM
For compound 4 the middle estimate is 3.3-fold (0.52 log units) below the measured one; measured number outside the range, above it.
By their numbers in this assay, from the lowest: compounds 3 and 4 (each within the scatter of the next); then compounds 2 and 1 (each within the scatter of the next).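

In this assay, trifluoromethyl in place of chloro at this position gives a 1.3-fold higher number from compound 3 to compound 4 (0.10 log units; within the scatter), so a group of four heavy atoms standing where a single heavy atom stood leaves the number within the scatter of the chloro compound. A larger count of heavy atoms at this place therefore did not carry the number further down, and the trifluoromethyl compound instead stands with the chloro compound, apart from the hydrogen and fluoro compounds: the steps are a 2.8-fold lower number from compound 2 to compound 4 (0.45 log units; beyond the scatter) and a 5.5-fold lower number from compound 1 to compound 4 (0.74 log units; beyond the scatter). Nothing in the data shown explains why the two groups give such similar numbers.

From the compounds shown here alone, what an amine or a carboxylic acid would give at this same place remains open. Also open, going by these compounds, is whether chloro and trifluoromethyl would match in the same way on another aromatic carbon of the shared core.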